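The source may report more compounds than this note shows. Statements on the series, on what has been measured and on what is new or still open speak of the compounds shown alone.

Compound 1 `Cc1ccc(CN(C)C(=O)c2nn(-c3ccc(F)cc3)c(OC[C@@H](O)C[C@@H](O)CC(=O)O)c2C(C)C)cc1` gives 37 nM in an assay on microsomes from liver for inhibition of 3-hydroxy-3-methylglutaryl-coenzyme A reductase (Rattus norvegicus); a lower number here means a stronger inhibitor, a higher number a weaker inhibitor.
Compound 2 `CC(C)c1c(C(=O)N2CCC[C@H](c3ccccc3)C2)nn(-c2ccc(F)cc2)c1OC[C@@H](O)C[C@@H](O)CC(=O)O` gives 4.8 nM in this assay.

Among the measured compounds shown here, compound 2 stands lowest of the two numbers in this assay; its only neighbour is compound 1, and the step of a 7.7-fold lower number from compound 1 to compound 2 (0.89 log units; beyond the scatter) lies beyond the scatter. Compound 3 `CC(C)c1c(C(=O)N2CCCCC2)nn(-c2ccc(F)cc2)c1OC[C@@H](O)C[C@@H](O)CC(=O)O` differs from compound 2 by hydrogen in place of phenyl on a saturated ring carbon. For the measured compounds named here, the one measured step that touches this part of the molecule is a 7.7-fold lower number from compound 1 to compound 2 (0.89 log units; beyond the scatter), in which the whole amide substituent was rebuilt and a modest gain followed. Going by the values given here, that step did not remove a phenyl by itself, so it bears only loosely on the present change; there is no measured pair that isolates the phenyl. A higher number is nonetheless expected, since part of what was gained in a 7.7-fold lower number from compound 1 to compound 2 (0.89 log units; beyond the scatter) may rest on the phenyl now taken away. The expected step is a 6.3-fold higher number from compound 2 to compound 3 (0.80 log units; beyond the scatter). Compound 3 is estimated at 30 nM, within a range from 8 nM to 110 nM.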

Compound 3, half-maximal inhibitory concentration: 47 nM
For compound 3 the middle estimate is 1.6-fold (0.19 log units) below the measured one; the measured number falls inside the stated range.
By their numbers in this assay, from the lowest: compound 2; then compounds 1 and 3 (each within the scatter of the next).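

Among the compounds shown here, removing the phenyl isolates this group on the ring for the first time: in this assay the change gives a 9.8-fold higher number from compound 2 to compound 3 (0.99 log units; beyond the scatter) and is the only measured step that alters nothing else. The plain piperidin-1-yl amide therefore does not by itself hold the low number of compound 2, and a 1.3-fold higher number from compound 1 to compound 3 (0.10 log units; within the scatter) shows that it cannot be told apart in this assay from the methyl(4-methylbenzyl)amino amide. Nothing at hand explains why the phenyl has this effect.

As far as these compounds go, it remains open whether a methyl, a cyclohexyl or a pyridyl on the same saturated ring carbon would keep the number of compound 2. Also open, from the compounds shown here alone, is how much depends on the configuration at that carbon, or on the phenyl standing two ring bonds from the ring nitrogen rather than elsewhere on the ring.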